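A few compounds are considered here, and "the series" means these few. Any claim that something is new, unique, unknown or untested is made for them only; others in the source may bear on it.

Measured in a functional assay on HepG2 cells (Homo sapiens) for antiproliferative activity, read by MTT assay; on this read-out lower numbers stand for stronger inhibition and higher numbers for weaker inhibition:
- Compound 1 `CC1(C)CCc2c(ccc(C(=O)/C=C/c3ccc(OCc4cn(-c5ccc(Br)cc5)nn4)cc3)c2O)O1`: 136000 nM
- Compound 2 `CC(=O)c1ccc(-n2cc(COc3ccc(/C=C/C(=O)c4ccc5c(c4O)CCC(C)(C)O5)cc3)nn2)cc1`: 91400 nM
- Compound 3 `CCCCCn1cc(COc2ccc(/C=C/C(=O)c3ccc4c(c3O)CCC(C)(C)O4)cc2)nn1`: 9820 nM

Compound 3 has the lowest number of the three, and its gaps to both others lie beyond the scatter. Compound 4 `CCCCCCCCn1cc(COc2ccc(/C=C/C(=O)c3ccc4c(c3O)CCC(C)(C)O4)cc2)nn1` differs from it only in the pentyl chain: propyl in place of hydrogen on a saturated chain carbon, five bonds along the chain from an aromatic nitrogen. For the measured compounds named here, no measured step alters a chain's length. The closest evidence is the exchange of an aryl group for pentyl on the aromatic nitrogen, which gave a 14-fold lower number from compound 1 to compound 3 (1.14 log units; beyond the scatter) and a 9.3-fold lower number from compound 2 to compound 3 (0.97 log units; beyond the scatter). The acetyl-for-bromo change, a 1.5-fold lower number from compound 1 to compound 2 (0.17 log units; within the scatter), lies elsewhere and says little here. With the chain already in place, no step beyond the scatter is expected in this assay, though the uncertainty is wide. The expected change is a 1.2-fold lower number from compound 3 to compound 4 (0.09 log units; within the scatter). For compound 4 the estimate is 8000 nM, within an expected range of 2500 nM to 30000 nM.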

Compound 4, half-maximal inhibitory concentration: 74100 nM
Estimate against measurement, compound 4: 9.3-fold (0.97 log units) below, and the stated range ends below it.
By their numbers in this assay, from the lowest: compound 3; then compounds 4, 2 and 1 (each within the scatter of the next).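

In this assay, the length of the chain on the aromatic nitrogen matters: adding propyl in place of hydrogen, five bonds along the chain from that nitrogen, gives a 7.5-fold higher number from compound 3 to compound 4 (0.88 log units; beyond the scatter). An alkyl chain alone therefore does not secure the advantage that pentyl holds over the aryl groups, since octyl gives a 1.2-fold lower number from compound 2 to compound 4 (0.09 log units; within the scatter) and a 1.8-fold lower number from compound 1 to compound 4 (0.26 log units; within the scatter), both within the scatter. No measurement here accounts for this loss. The compounds shown leave open how butyl, hexyl or heptyl chains would compare with pentyl and octyl. They also leave open whether a pentyl chain ending in an amine or a carboxylic acid would keep the number of compound 3.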